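A methoxy added to a compound sitting at the limit

The source may report more compounds than this note shows. Statements on the series, on what has been measured and on what is new or still open speak of the compounds shown alone.

Compound 2 `O=C(Nc1cccc(-c2nc3ccccc3s2)c1)c1cnccc1Cl` carries a 4-chloropyridin-3-yl group on the carbonyl carbon of its amide. In an ADME assay on HEK293 cells (Homo sapiens) for inhibition, with a stated time of 72 h (a lower number here means that less compound is needed, a higher number that more compound is needed for the effect), compound 2 gives > 25000 nM, which is a limit of the measurement rather than a number. Compound 1 `CN(C)CCC(=O)Nc1cccc(-c2nc3ccccc3s2)c1` gives only a limit in this assay as well, at > 25000 nM. Compound 3 `O=C(Nc1cccc(-c2nc3ccccc3s2)c1)c1cnc(Cl)s1` likewise gives only a limit in this assay, at > 25000 nM. Because every value sits at the limit of > 25000 nM in this assay, at which 3 of the 3 values shown sit, the steps a step that the two limits leave unreadable from compound 1 to compound 2, a step that the two limits leave unreadable from compound 1 to compound 3 and a step that the two limits leave unreadable from compound 2 to compound 3 cannot be sized. Compound 4 `COc1ccc(-c2nc3ccccc3s2)cc1NC(=O)c1cnccc1Cl` differs from compound 2 by methoxy in place of hydrogen on an aromatic carbon. For the measured compounds named here, no measured step bears on this change, so neither its size nor its direction can be read. Compound 4 is expected to give 30000 nM in this assay, with a range from 8000 nM to 100000 nM. The expected step is then a step that the limit leaves unreadable from compound 2 to compound 4, most likely again only a limit.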

Compound 4, half-maximal effective concentration: > 25000 nM
Compound 4 ended at the assay's limit; the forecaster's own chance of this, stated with the estimate: 85%; the middle value does not contradict the limit.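

Compound 2 and compound 4 both sit at the limit of the measurement, so no size or direction can be read for the added methoxy: the limit of > 25000 nM in this assay, at which 4 of the 4 values shown sit.

The compounds shown leave open which change, if any, would give a measurable value in this assay.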